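The source may report more compounds than this note shows. Statements on the series, on what has been measured and on what is new or still open speak of the compounds shown alone.

Measured compounds:

Compound 1, `COc1ccccc1-c1cnc(NC(=O)c2ccc(F)cc2)n1C`. In a toxicity assay on THP-1 cells (Homo sapiens) for inhibition (on this read-out lower numbers stand for higher toxicity in this test and higher numbers for lower toxicity in this test), compound 1 reaches only a limit, > 100000 nM.
Compound 2, `COc1ccc(CNC(=O)NC(=O)c2ccc(F)cc2)cc1`. In this assay compound 2 reaches only a limit, > 50000 nM.
Compound 3, `COc1ccc(-c2cnc(NC(=O)c3ccn[nH]3)n2C)cc1`. In this assay compound 3 reaches only a limit, > 100000 nM.

Compound 1 thus stands at a limit rather than at a number, and it shares (the limit of > 100000 nM in this assay, at which 2 of the 3 values shown sit). Compound 2 sits at the limit of > 50000 nM in this assay, at which 1 of the 3 values shown sits. Going by the values given here, none of the three compounds gives a real value, so no step between measured compounds can be read, and nothing separates compound 1 from the others beyond the fact that all three show low toxicity in this assay.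

Compound 4, `Cn1c(-c2ccccc2Br)cnc1NC(=O)c1ccc(F)cc1`, is not yet measured. Against compound 1 it shows (bromo in place of methoxy on an aromatic carbon). Among the compounds with values here, with no measured step to draw on and all three known values at a limit, the step from compound 1 to compound 4 is expected to lie within the scatter, with no direction favoured. The estimate for compound 4 in this assay is 100000 nM, between 30000 nM and 300000 nM, which means an expected step of a number no higher from compound 1 to compound 4 (the limit leaves the size open). A limit rather than a number is expected for compound 4.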

Compound 4, half-maximal cytotoxic concentration: > 100000 nM
Compound 4: a limit, no number; the forecaster's own chance of this, stated with the estimate: 80%; the middle value lies on the limit itself.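

Going by these compounds alone, compound 1 and compound 4 both reach only a limit in this assay, so bromo in place of methoxy gives no step that can be read. The compounds shown leave open which structural change, if any, would give a real value in this assay.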